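A few compounds are considered here, and "the series" means these few. Any claim that something is new, unique, unknown or untested is made for them only; others in the source may bear on it.

Measured in a physicochemical assay for solubility, read by spectrophotometry, using the shake flask method, with a stated time of 2 days, at pH 6.5; on this read-out higher numbers stand for higher solubility and lower numbers for lower solubility:

- compound 1 `Oc1ccc(-n2cc(-c3ccc4cc(OCC5CCCCO5)ccc4n3)nn2)cc1`: 3.4 ug/mL
- compound 2 `Oc1ccc(-n2cc(-c3ccc4ccccc4n3)nn2)cc1`: 2.2 ug/mL
- compound 3 `OCCOc1ccc2nc(-c3cn(-c4ccc(O)cc4)nn3)ccc2c1`: 2.6 ug/mL

Compound 3, at 2.6 ug/mL, lies within the usual scatter of the other two compounds. Compound 4 `NCCOc1ccc2nc(-c3cn(-c4ccc(O)cc4)nn3)ccc2c1` differs from it as follows: amino in place of hydroxy on a saturated chain carbon, two bonds along the chain from an oxygen on an aromatic ring. This puts amino in place of hydroxy on a saturated chain carbon, two bonds along the chain from an oxygen on an aromatic ring. The nearest evidence is a 1.2-fold higher number from compound 2 to compound 3 (0.07 log units; within the scatter) and a 1.3-fold lower number from compound 1 to compound 3 (0.12 log units; within the scatter). Within the data shown here, both changes altered this same side chain, yet neither swapped hydroxy for amino, so no measured step tests this change directly. A modest rise is therefore only a judgement, and the expected step is a 3.1-fold higher number from compound 3 to compound 4 (0.49 log units; beyond the scatter). Compound 4 is estimated at 8 ug/mL, with an expected range from 2.5 ug/mL to 30 ug/mL.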

Compound 4, solubility: 3.7 ug/mL
For compound 4 the middle estimate is 2.2-fold (0.33 log units) above the measured one; the measured number falls inside the stated range.
By their numbers in this assay, from the lowest: compounds 2, 3, 1 and 4 (each within the scatter of the next).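

In this assay the direct test of amino in place of hydroxy at this chain position gives a 1.4-fold higher number from compound 3 to compound 4 (0.15 log units; within the scatter) and so stays within the usual scatter. The other two comparisons also stay within it: 2-aminoethoxy in place of hydrogen gives a 1.7-fold higher number from compound 2 to compound 4 (0.23 log units; within the scatter) and aminomethyl in place of oxan-2-yl gives a 1.1-fold higher number from compound 1 to compound 4 (0.04 log units; within the scatter) on the shared core. No supporting measurement here offers an explanation for these results. Still open, on these data alone, is whether a carboxylic acid at this chain end would separate from these four compounds. A longer chain carrying the amine leaves the same question open.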